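Inverting One Ring Stereocentre in a Dopamine Transporter Series

The source may hold more compounds than are shown below. What is called first, only, known or untested is meant among the compounds shown, and "the series" means these compounds.

Among the compounds with values here, compound 3 `CN1CC[C@@H](c2ccc(Cl)cc2)[C@H](CSCCOC(=O)c2ccccc2)C1` gives 378 nM in an assay on a subcellular fraction from brain with sodium-dependent dopamine transporter (Rattus norvegicus) as the target (on this read-out higher numbers stand for weaker inhibition and lower numbers for stronger inhibition), the second highest of the three numbers measured so far. Compound 2 `CC(=O)OCCSC[C@@H]1CN(C)CC[C@H]1c1ccc(Cl)cc1` gives 536 nM, and the change to compound 3 is a 1.4-fold lower number from compound 2 to compound 3 (0.15 log units; within the scatter). Compound 1 `CC(=O)OCCSC[C@H]1CN(C)CC[C@H]1c1ccc(Cl)cc1` gives 177 nM. Compound 4 `CN1CC[C@@H](c2ccc(Cl)cc2)[C@@H](CSCCOC(=O)c2ccccc2)C1` differs from compound 3 in a single respect: the two compounds have the same atoms and bonds and differ only in configuration as drawn: 1 of 2 stereo elements differ; a stereocentre at a saturated ring carbon is drawn S in compound 3 and R in compound 4. The same kind of switch has already been measured: a 3.0-fold higher number from compound 1 to compound 2 (0.48 log units; beyond the scatter), a step that rests on (the fact that compounds 1 and 2 differ only in the configuration as drawn). Compound 4 reverses the drawn configuration in the opposite sense, so a lowering of the number of about that size is expected. Compound 4 is therefore estimated at 126 nM, with a range from 60 nM to 260 nM, the expected step being a 3.0-fold lower number from compound 3 to compound 4 (0.48 log units; beyond the scatter).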

Compound 4, inhibition constant: 1470 nM
The estimate for compound 4 lay 12-fold (1.07 log units) below the measured number; measured number outside the range, above it.
By their numbers in this assay, from the lowest: compound 1; then compounds 3 and 2 (each within the scatter of the next); then compound 4.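

Inverting this ring stereocentre does not have one fixed effect: the configuration of compound 1 gives the lower number with methyl on the carbonyl carbon, but the configuration of compound 3 gives the lower number with phenyl there, with a 3.9-fold higher number from compound 3 to compound 4 (0.59 log units; beyond the scatter). Phenyl in place of methyl also depends on configuration, with an 8.3-fold higher number from compound 1 to compound 4 (0.92 log units; beyond the scatter), and the change does not carry over between the two stereoisomeric cores: the same change on two cores in this assay, a 1.4-fold lower number (0.15 log units; within the scatter) from compound 2 to compound 3 and an 8.3-fold higher number (0.92 log units; beyond the scatter) from compound 1 to compound 4, 12-fold (1.07 log units) apart, beyond the scatter of two such steps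

The compounds shown leave open whether this reversal would persist with a longer chain on the carbonyl carbon. They also leave open what an amide in place of the ester would do at either configuration.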